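A few compounds are considered here, and "the series" means these few. Any claim that something is new, unique, unknown or untested is made for them only; others in the source may bear on it.

Compound 1 `O=C(/C=C/c1ccc2c(c1)B(O)OC2)c1cccnc1` gives 76200 nM in a toxicity assay on WI-38 cells (Homo sapiens) for cytotoxicity, read by MTT assay, with a stated time of 48 h; a higher number here means a weaker inhibitor, a lower number a stronger inhibitor.
Compound 2 `Cn1cccc1C(=O)/C=C/c1ccc2c(c1)B(O)OC2` gives > 100000 nM in this assay, which is a limit of the assay rather than a number.
Compound 3 `O=C(/C=C/c1ccc2c(c1)B(O)OC2)c1ccc(O)cc1` gives > 100000 nM in this assay, again a limit and not a number.

Compound 3 thus stands at the weak end of what this assay can report, where two of the three values sit (the limit of > 100000 nM in this assay, at which 2 of the 3 values shown sit). Compound 4 `O=C(/C=C/c1ccc2c(c1)B(O)OC2)c1ccccc1O` differs from compound 3 by 2-hydroxyphenyl in place of 4-hydroxyphenyl on a carbonyl carbon. Among the compounds with values here, no measured step changes the position of a group on that ring; the steps that touch the 4-hydroxyphenyl end, an at least 1.3-fold higher number from compound 1 to compound 3 (0.11 log units; that floor lies within the scatter) and a step that the two limits leave unreadable from compound 2 to compound 3, only show it at or near the limit. Compound 4 is therefore expected to show a number no higher from compound 3 to compound 4 (the limit leaves the size open), most likely remaining a limit. Compound 4 is estimated at 100000 nM, between 40000 nM and 300000 nM.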

Compound 4, half-maximal inhibitory concentration: > 100000 nM
Compound 4: no number, only a limit; the forecaster's own chance of this, stated with the estimate: 65%; the middle value lies on the limit itself.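

Putting 2-hydroxyphenyl in place of 4-hydroxyphenyl on the carbonyl carbon gives no readable change in this assay, so both hydroxyphenyl compounds now rest on a limit and not a number: the limit of > 100000 nM in this assay, at which 3 of the 4 values shown sit.
Within the data shown here, the only readable step is an at least 1.3-fold higher number from compound 1 to compound 4 (0.11 log units; that floor lies within the scatter), and the steps from the other two compounds cannot be read.

On these data alone, how far compound 3 and compound 4 lie past the limit stays open, so any real difference between them remains hidden. Also open, as far as these compounds go, is whether an amine or a carboxylic acid on this ring would give a readable number.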